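Swapping the Side Chain Beside a Purine-Bearing Amide

A few compounds are considered here, and "the series" means these few. Any claim that something is new, unique, unknown or untested is made for them only; others in the source may bear on it.

Compound 1 `O=C(CN(c1nc(Cl)nc2[nH]cnc12)C1CC1)NCC(=O)OCc1ccccc1` gives 27.2% in a functional assay on the whole organism (Tail, strain ICR) with Mus musculus as the target, in the tail flick test, with a stated time of 90 min, at a dose of 25 umol/kg by the oral route; a higher number here means a stronger effect of the compound at the dose given, a lower number a weaker effect.
Compound 2 `CC(C)[C@H](NC(=O)CN(c1nc(Cl)nc2[nH]cnc12)C1CC1)C(=O)OCc1ccccc1` gives 51.3%.
Compound 3 `O=C(OCc1ccccc1)[C@@H]1CCCN1C(=O)CN(c1nc(Cl)nc2[nH]cnc12)C1CC1` gives 43.3%.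

Among these three numbers compound 2 stands highest. Its nearest neighbour is compound 3, whose number lies within the scatter of it, so no order between those two can be claimed; compound 1 lies beyond the scatter below compound 2.

Compound 4 `O=C(CN(c1nc(Cl)nc2[nH]cnc12)C1CC1)N[C@@H](CCC(=O)OCc1ccccc1)C(=O)OCc1ccccc1` differs from compound 2 at a single place: 2-(benzyloxycarbonyl)ethyl in place of isopropyl on a saturated chain carbon bound to an amide-type nitrogen and a carbonyl carbon. Going by the values given here, only one measured step touches this spot, a number 24.1 percentage points higher from compound 1 to compound 2 (beyond the scatter), where isopropyl replaced hydrogen. That step suggests a group on this carbon is not harmful, but the entering 2-(benzyloxycarbonyl)ethyl is far larger than isopropyl and unlike anything measured, so its effect cannot be read from the data. The expected step from compound 2 is therefore small, a number 9.3 percentage points lower from compound 2 to compound 4 (within the scatter), within the scatter in this assay. The estimate for compound 4 is 42%, ranging from 22% to 62%.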

Compound 4, a percentage reported as activity, at one dose (the size of the read-out at that dose, not a potency): 50%
For compound 4 the middle estimate is 8 percentage points below the measured one; the measured number falls inside the stated range.
By their numbers in this assay, from the lowest: compound 1; then compounds 3, 4 and 2 (each within the scatter of the next).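

On the saturated chain carbon bound to an amide-type nitrogen and a carbonyl carbon, this assay shows that the far larger 2-(benzyloxycarbonyl)ethyl can take the place of isopropyl with no readable loss: the change gives a number 1.3 percentage points lower from compound 2 to compound 4 (within the scatter). Measured against hydrogen, the same group gives a number 22.8 percentage points higher from compound 1 to compound 4 (beyond the scatter), so the gain first seen with isopropyl is not confined to that one small group. Nothing available here tells what lies behind this result.

Going by these compounds, whether a carboxylic acid or an amine at the end of this side chain would keep the number at the level of compound 2 and compound 4 remains open. So does the effect of a plain unbranched hexyl chain on this carbon, which would carry no ester and no aromatic ring.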